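The source may report more compounds than this note shows. Statements on the series, on what has been measured and on what is new or still open speak of the compounds shown alone.

Measured in an ADME assay on RAW264.7 cells (Mus musculus) for cytotoxicity, read by MTT assay, with a stated time of 24 h, in the absence of a further agent; on this read-out higher numbers stand for weaker inhibition and lower numbers for stronger inhibition:
- compound 1 `CCC(C)Oc1ccc(C(O)C2OC(=O)c3c(OC)cc(OC)cc32)cc1`: > 40000 nM
- compound 2 `CCOCCOc1ccc(C(O)C2OC(=O)c3c(OC)cc(OC)cc32)cc1`: > 40000 nM
- compound 3 `C=CCCOc1ccc(C(O)C2OC(=O)c3c(OC)cc(OC)cc32)cc1`: > 40000 nM

All three entries are limits, not numbers. Compound 3 has no place of its own in the series, and the whole set stands together at the limit of > 40000 nM in this assay, at which 3 of the 3 values shown sit.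

The next change leads to compound 4 `COc1cc(OC)c2c(c1)C(C(O)c1ccc(OCc3ccc(F)cc3)cc1)OC2=O`, with 4-fluorophenyl in place of allyl on a saturated chain carbon bound to an oxygen on an aromatic ring. Cut one bond further out, this reads but-3-en-1-yl to 4-fluorobenzyl.

Within the data shown here, three measured steps bear on it. On the same oxygen there are a step that the two limits leave unreadable from compound 1 to compound 2 and a step that the two limits leave unreadable from compound 1 to compound 3, and further along the chain there is a step that the two limits leave unreadable from compound 2 to compound 3. None of the three has a readable size, so they set no scale and no direction for the new change. Compound 1, compound 2 and compound 3 also carry no ring in this place, so the change goes beyond what they cover.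

No shift beyond the usual scatter is expected in this assay, and the expected step is a step that the limit leaves unreadable from compound 3 to compound 4. Compound 4 will most likely be reported as a limit again. As a value, compound 4 is estimated at 50000 nM, with an expected range of 22000 nM to 100000 nM.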

Compound 4, half-maximal inhibitory concentration: > 40000 nM
Compound 4: only a limit was reported (the forecaster's own chance of this, stated with the estimate: 75%); the middle value does not contradict the limit.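

In this assay, compound 4 is again a limit and not a number, so none of its steps from compound 1, compound 2 or compound 3 can be read, and the series stands together: the limit of > 40000 nM in this assay, at which 4 of the 4 values shown sit.

The compounds shown leave open how these four rank against each other and which change on the oxygen on the aromatic ring, if any, would give a readable value in this assay.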